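A few compounds are considered here, and "the series" means these few. Any claim that something is new, unique, unknown or untested is made for them only; others in the source may bear on it.

Working notes on the series. Compound 1 `Nc1nc(-c2ccc(Cl)o2)nc2sc(CN3CCCC3)cc12` gives 710 nM in an assay on CHO-K1 cells for antagonist activity at adenosine receptor A1 (Homo sapiens), read by a beta-galactosidase reporter, with stated times of 15 min and 6 h; a higher number here means a weaker inhibitor, a lower number a stronger inhibitor. Compound 2 `Nc1nc(-c2ccc(Cl)o2)nc2sc(CN3CCC(F)CC3)cc12` gives 1080 nM in this assay, and compound 3 `Nc1nc(-c2ccc(Cl)o2)nc2sc(CN3CC=CC3)cc12` gives 780 nM. Compound 2 holds the largest of the three numbers, yet a 1.5-fold higher number from compound 1 to compound 2 (0.18 log units; within the scatter) and a 1.4-fold lower number from compound 2 to compound 3 (0.14 log units; within the scatter) both sit within the scatter, as does a 1.1-fold higher number from compound 1 to compound 3 (0.04 log units; within the scatter); the three cyclic amines do not separate on these data.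

Compound 4 `Nc1nc(-c2cccc([N+](=O)[O-])c2)nc2sc(CN3CCC(F)CC3)cc12` differs from compound 2 in 3-nitrophenyl in place of 5-chlorofuran-2-yl on an aromatic carbon. Every measured step in the series changes only the cyclic amine on the saturated chain carbon; not one of them touches the aromatic carbon where the 5-chlorofuran-2-yl sits. Going by the values given here, no measured step bears on the change from compound 2 to compound 4, so neither its direction nor its size can be read from the series, and the expectation is anchored on compound 2 with a wide range in this assay. Compound 4 is expected at 1100 nM, with a range of 250 nM to 5000 nM. For compound 4 the expected step is a 1.0-fold higher number from compound 2 to compound 4 (0.01 log units; within the scatter), reflecting no grounds for a shift beyond the scatter.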

Compound 4, inhibition constant: > 10000 nM
Compound 4 gave a limit, no number; the forecaster's own chance of this, stated with the estimate: 10%; at least 9.0-fold (0.95 log units) between middle value and limit.
By their numbers in this assay, from the lowest: compounds 1, 3 and 2 (each within the scatter of the next). At a limit, above all of these: compound 4.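

Going by these compounds alone, this is the first measured change at the aromatic carbon between two ring nitrogen atoms, and it weighs far more than any change of the cyclic amine: 3-nitrophenyl in place of 5-chlorofuran-2-yl gives an at least 9.2-fold higher number from compound 2 to compound 4 (0.96 log units; beyond the scatter). In this assay compound 4 gives > 10000 nM, which is a limit of the assay and not a number. The step therefore has a lower bound only, with no upper bound: the limit of > 10000 nM in this assay, at which 1 of the 4 values shown sits.

The change replaces ring and substituent at once, and the compounds shown do not separate the loss of 5-chlorofuran-2-yl from the entry of 3-nitrophenyl. Open too, on these data alone, is whether a plain phenyl or a furan-2-yl without the chlorine at this carbon would stay close to compound 2.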